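Methoxy-substituted deazapurine nucleosides: the iodo analogue

The compounds below may be only part of what the source reports. "The series", "measured", "known", "first", "only" and "open" are said of these compounds alone.

Measured so far in a functional assay on K562 cells (Homo sapiens), read by MTT assay, with a stated time of 72 h; a higher number here means a weaker inhibitor, a lower number a stronger inhibitor:
compound 1, `COc1ncnc2c1c(-c1cccs1)cn2[C@@H]1O[C@H](CO)[C@@H](O)[C@H]1O`, 6200 nM
compound 2, `COc1nc(N)nc2c1c(-c1cccs1)cn2[C@@H]1O[C@H](CO)[C@@H](O)[C@H]1O`, > 20000 nM
compound 3, `CSc1ncnc2c1c(-c1cccs1)cn2[C@@H]1O[C@H](CO)[C@@H](O)[C@H]1O`, > 20000 nM

Within the data shown here, compound 1 holds the only actual number in this assay ; compound 2 returns a limit of the assay, > 20000 nM, and compound 3 likewise returns a limit, > 20000 nM. Both single-point changes from compound 1 thus weakened inhibition: an at least 3.2-fold higher number from compound 1 to compound 2 (0.50 log units; beyond the scatter), and an at least 3.2-fold higher number from compound 1 to compound 3 (0.50 log units; beyond the scatter). In each case the result sits at the limit of > 20000 nM in this assay, at which 2 of the 3 values shown sit, so the true size of either step is not known.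

Compound 4, `COc1ncnc2c1c(I)cn2[C@@H]1O[C@H](CO)[C@@H](O)[C@H]1O`, is the next member. (iodo in place of thiophen-2-yl on an aromatic carbon). Neither measured step touches this position; the two steps recorded alter the methoxy side of the core or add an amino group elsewhere, so they say nothing direct about exchanging the thiophen-2-yl group for iodo. What they do show is that every departure from compound 1 measured so far has lost potency, and compound 1 itself is only a weak inhibitor. With no closer guide, a weakening is taken as the more likely outcome, with a wide range and a real chance that the assay again reports only a limit. Compound 4 is therefore estimated at 12000 nM in this assay , within 3000 nM to 40000 nM, an expected step of a 1.9-fold higher number from compound 1 to compound 4 (0.29 log units; within the scatter).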

Compound 4, half-maximal inhibitory concentration: 14800 nM
Compound 4: the middle estimate sits 1.2-fold (0.09 log units) below what was measured, within the range that was stated.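

Exchanging thiophen-2-yl for iodo on this aromatic carbon gives, in this assay, a 2.4-fold higher number from compound 1 to compound 4 (0.38 log units; beyond the scatter). The position therefore affects the read-out, but the thiophen-2-yl ring is not needed for a measurable value: a single iodine in place of a group of 5 heavy atoms costs only a modest step, although compound 1 keeps the lower number. Compound 4 also gives the first step from compound 1 whose size can be read, since its result is an actual number and stays clear of the limit that holds compound 2 and compound 3: the limit of > 20000 nM in this assay, at which 2 of the 4 values shown sit.

With only thiophen-2-yl and iodo shown at this position, the data cannot separate the effect of removing the ring from the effect of introducing iodine, and a phenyl ring, a furan-2-yl ring, a methyl group or an amine there could help to make that distinction. It also remains open whether the iodo group would change the outcome of the amino addition or of the exchange of methoxy for methylsulfanyl, as both changes are shown only alongside thiophen-2-yl.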